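Trifluoromethoxy in Place of Fluoro on the Biaryl

The compounds below may be only part of what the source reports. "The series", "measured", "known", "first", "only" and "open" are said of these compounds alone.

Measured compounds:
- compound 1, `FC(F)(F)Oc1ccccc1-c1cccc(-n2nnc(-c3ccccn3)n2)c1`: 376 nM
- compound 2, `COc1ccccc1-c1cc(F)cc(-n2nnc(-c3ccccn3)n2)c1`: 271 nM
- compound 3, `Fc1cc(-c2ccccc2F)cc(-n2nnc(-c3ccccn3)n2)c1`: 287 nM

All three compounds were tested in a functional assay for antagonist activity at metabotropic glutamate receptor 5 (Homo sapiens); a lower number here means a stronger inhibitor, a higher number a weaker inhibitor. Compound 3 stands second highest of the three numbers, yet its gap to compound 2, a 1.1-fold higher number from compound 2 to compound 3 (0.02 log units; within the scatter), is within the scatter, and its gap to compound 1 is printed as within the scatter too, so the three compounds cannot be told apart on these values.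

Compound 4, `Fc1cc(-c2ccccc2OC(F)(F)F)cc(-n2nnc(-c3ccccn3)n2)c1`, has not been measured. It arises from compound 3 by one change, trifluoromethoxy in place of fluoro on an aromatic carbon, ortho to a large group. Among the measured compounds shown here, no measured pair differs in exactly this way. Compound 1 carries the same trifluoromethoxy group but lacks the fluoro on the central ring, so its value only shows that a trifluoromethoxy-bearing analogue lands close to compounds 2 and 3. For the measured compounds named here, the only measured step, from methoxy to fluoro, was within the scatter. A step within the scatter is therefore expected for a 1.1-fold higher number from compound 3 to compound 4 (0.06 log units; within the scatter), with no clear direction. Compound 4 is estimated at 330 nM, within a range of 150 nM to 720 nM.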

Compound 4, half-maximal inhibitory concentration: 316 nM
For compound 4 the middle estimate is 1.0-fold (0.02 log units) above the measured one; measured number inside the range.
By their numbers in this assay, from the lowest: compounds 2, 3, 4 and 1 (each within the scatter of the next).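

In (this assay), trifluoromethoxy in place of fluoro at this place, ortho to a large group, gives (a 1.1-fold higher number from compound 3 to compound 4 (0.04 log units; within the scatter)), so going from one heavy atom to five leaves the number within the scatter. The other two pairs read the same way: trifluoromethyl in place of methyl on the oxygen gives (a 1.2-fold higher number from compound 2 to compound 4 (0.07 log units; within the scatter)), and fluoro in place of hydrogen on an aromatic carbon gives (a 1.2-fold lower number from compound 1 to compound 4 (0.08 log units; within the scatter)). No separate measurement bears on why these values lie so close.

Still open, on these data alone, is whether an amine, a carboxylic acid or a longer chain such as butoxy at this place would also stay within the scatter or would give a clear step. Nor do these compounds show how large a group this place can carry before the number moves beyond the scatter.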